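This account rests on a few compounds, and the source may have more. Where it says the series, first, only, none or still open, it means among the compounds named here.

Compound 1 `O[C@@H](c1ccccc1)[C@H]1CO[C@H](c2ccccc2)[C@@H](C/C=C/c2ccncc2)C1` carries pyridin-4-yl on a double-bonded chain carbon bound to a double-bonded chain carbon. In a functional assay on HeLa cells (Homo sapiens) for cytotoxicity, read by WST assay, with a stated time of 48 h (a higher number here means a weaker inhibitor, a lower number a stronger inhibitor), compound 1 reaches only a limit, > 100000 nM, that is the limit of > 100000 nM in this assay, at which 1 of the 2 values shown sits. Going by the values given here, compound 2 `O[C@@H](c1ccccc1)[C@H]1CO[C@H](c2ccccc2)[C@@H](C/C=C/c2cccc(F)c2)C1`, with 3-fluorophenyl at that place, gives 8380 nM in this assay and so holds the only number in the set. Among the compounds with values here, the one measured step, an at least 11-fold lower number from compound 1 to compound 2 (1.07 log units; beyond the scatter), is large. Compound 3 `Oc1ccc(/C=C/C[C@H]2C[C@@H]([C@@H](O)c3ccccc3)CO[C@@H]2c2ccccc2)cc1` differs from compound 2 by 4-hydroxyphenyl in place of 3-fluorophenyl on a double-bonded chain carbon bound to a double-bonded chain carbon. Within the data shown here, no measured step involves 4-hydroxyphenyl, so that large step bears on it only as a sign that this aryl position matters. The expected step is small, a 1.8-fold higher number from compound 2 to compound 3 (0.25 log units; within the scatter), a slight loss within or just beyond the scatter. In this assay compound 3 is estimated at 15000 nM, ranging from 4000 nM to 60000 nM.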

Compound 3, half-maximal inhibitory concentration: 14400 nM
For compound 3 the middle estimate is 1.0-fold (0.02 log units) above the measured one; low and high end bracket the measured number.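

In this assay, a hydrogen-bond donor and acceptor can enter on this aryl group without a shift past the scatter: a 1.7-fold higher number from compound 2 to compound 3 (0.24 log units; within the scatter). The gap to the pyridin-4-yl compound is therefore not peculiar to 3-fluorophenyl, as 4-hydroxyphenyl also separates from it, with an at least 6.9-fold lower number from compound 1 to compound 3 (0.84 log units; beyond the scatter). Compound 1 stands only at a limit, so the true size of both gaps stays unknown: the limit of > 100000 nM in this assay, at which 1 of the 3 values shown sits.

The swap alters both the substituent and its ring position, so 3-hydroxyphenyl and 4-fluorophenyl would be needed to separate the two. Unsubstituted phenyl, an amine or a carboxylic acid at this place also remain open.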